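A few compounds are considered here, and "the series" means these few. Any claim that something is new, unique, unknown or untested is made for them only; others in the source may bear on it.

Going by the values given here, in a functional assay on the whole organism (artery, strain albino) with Rattus norvegicus as the target, with a stated time of 900 min, at a dose of 10 mg/kg by the oral route (on this read-out lower numbers stand for less inhibition and higher numbers for more inhibition at the one dose given (going by the name of the read-out)), compound 3 `CC1=C(C(=O)Nc2ccc(Br)cc2)C(c2ccc(Cl)cc2Cl)N=C(SCc2ccccc2Cl)N1` gives 16.4%, the highest of the three numbers so far. Compound 2 `CC1=C(C(=O)Nc2ccc(Br)cc2)C(c2ccc(Cl)cc2Cl)N=C(SCc2ccccc2)N1` gives 8.2%, and compound 1 `COc1ccc(C2N=C(SCc3ccccc3)NC(C)=C2C(=O)Nc2ccc(F)cc2)cc1OC` gives 1%; the step of a number 8.2 percentage points higher from compound 2 to compound 3 (within the scatter) stays within the scatter, whereas the gap from compound 1 to compound 3 lies beyond it. Compound 4 `CC1=C(C(=O)Nc2ccc(Br)cc2)C(c2ccc(Cl)cc2Cl)N=C(SCc2cccc(Cl)c2)N1` differs from compound 3 in one respect: 3-chlorophenyl in place of 2-chlorophenyl on a saturated chain carbon bound to a sulfur. Among the compounds with values here, the only measured step that bears on this change, a number 8.2 percentage points higher from compound 2 to compound 3 (within the scatter), introduced that same chlorine and did not move the read-out beyond the scatter, so the shift from 2-chlorophenyl to 3-chlorophenyl is expected to give no step beyond the scatter, a number 2.4 percentage points lower from compound 3 to compound 4 (within the scatter). Compound 4 is therefore estimated at 14%, within a range from 2% to 28%.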

Compound 4, a percentage reported as inhibition, in the whole organism at one dose (the size of the read-out at that dose, not a potency): 7.2%
Beside the measured number, compound 4's estimate is 6.8 percentage points above it; the range from low to high includes it.
By their numbers in this assay, from the lowest: compounds 1, 4, 2 and 3 (each within the scatter of the next, the first and the last beyond it).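

In this assay, the place on a saturated chain carbon bound to a sulfur has now been probed with the chlorine in two arrangements: 3-chlorophenyl in place of 2-chlorophenyl gives a number 9.2 percentage points lower from compound 3 to compound 4 (within the scatter), and chloro in place of hydrogen, this time leading to 3-chlorophenyl, gives a number 1 percentage points lower from compound 2 to compound 4 (within the scatter). Neither step leaves the scatter, so this read-out does not separate compound 2, compound 3 and compound 4. No measurement at hand accounts for these small steps. Still open, on these data alone, is whether an amine or a carboxylic acid in place of the chlorine would produce a step beyond the scatter.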